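The source may report more compounds than this note shows. Statements on the series, on what has been measured and on what is new or still open speak of the compounds shown alone.

Compound 1 `COc1ccc(N(C)c2nc(C)nc3ccccc23)cc1OCCC[Se]C#N`: 815 nM
Compound 2 `COc1ccc(N(C)c2nc(C)nc3ccccc23)cc1OCCCCCC[Se]C#N`: 3550 nM

In a functional assay on MDA-MB-231 cells (Homo sapiens) for inhibition, read by MTT assay, with a stated time of 48 h (a higher number here means a weaker inhibitor, a lower number a stronger inhibitor), compound 2 gives 3550 nM, the higher of the two numbers and so the weaker inhibitor of this pair. Going by the values given here, the one measured step that bears on what follows is a 4.4-fold higher number from compound 1 to compound 2 (0.64 log units; beyond the scatter). It is a modest step, beyond the scatter, and it goes with a longer saturated chain.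

The next compound is compound 3 `COc1ccc(N(C)c2nc(C)nc3ccccc23)cc1C(=O)OCCC[Se]C#N`. The change is a group of 9 heavy atoms (5 carbon, 1 nitrogen, 2 oxygen, 1 selenium; no ring) in place of a group of 10 heavy atoms (7 carbon, 1 nitrogen, 1 oxygen, 1 selenium; no ring), on an aromatic carbon, on an aromatic carbon, ortho to a methoxy group. Among the compounds with values here, compound 3 carries the shorter chain of compound 1, which gives 815 nM, but the chain is joined to the ring through a new link containing a double bond, and no measured compound tests that link. A move back toward a lower number is therefore expected, though with real uncertainty. The estimated change is a 2.7-fold lower number from compound 2 to compound 3 (0.44 log units; beyond the scatter). For compound 3 the expected value is 1300 nM, with an estimated range of 450 nM to 3500 nM.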

Compound 3, half-maximal inhibitory concentration: 1180 nM
Estimate against measurement, compound 3: 1.1-fold (0.04 log units) above; measured number inside the range.
By their numbers in this assay, from the lowest: compounds 1 and 3 (each within the scatter of the next); then compound 2.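

On the aromatic carbon ortho to a methoxy group, the ether link of compound 1 can give way to the carbonyl link of compound 3 with no change that can be told from the scatter in this assay (a 1.4-fold higher number from compound 1 to compound 3 (0.16 log units; within the scatter)), so this position accepts either link when the chain is short. The step of a 3.0-fold lower number from compound 2 to compound 3 (0.48 log units; beyond the scatter) lies beyond the scatter, but it changes the link and the chain length together, so it cannot show which of the two matters. No measurement here explains why these numbers fall as they do.

Going by these compounds, it remains open whether a longer chain on the carbonyl link would raise the number as it does on the ether link. An amide link at this position is also untested among the compounds shown, as is a chain of intermediate length.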